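Imidazole-biphenyl acid series: neopentyl to phenyl swap

The source may hold more compounds than are shown below. What is called first, only, known or untested is meant among the compounds shown, and "the series" means these compounds.

Measured compounds:
compound 1 `CCCCc1cnc(C(CCCC)Cc2ccc(-c3ccccc3C(=O)O)cc2)[nH]1` gives 2660 nM
compound 2 `CC(C)(C)CCc1cnc(CCc2ccc(-c3ccccc3C(=O)O)cc2)[nH]1` gives 39 nM
compound 3 `CCCCc1cnc(C(C)Cc2ccc(-c3ccccc3C(=O)O)cc2)[nH]1` gives 2760 nM

In an in vitro functional assay on cells for agonist activity at Bombesin receptor subtype-3 (Homo sapiens), read by luminescence and calcium flux (a lower number here means that less compound is needed, a higher number that more compound is needed for the effect), compound 2 stands lowest of the three numbers, with compound 1 and compound 3 both higher by margins beyond the scatter. Among the compounds with values here, the only single-place step among the measured compounds, a 1.0-fold higher number from compound 1 to compound 3 (0.02 log units; within the scatter), concerns the saturated chain carbon two bonds from the aromatic carbon, not the position altered here, so it gives no guidance on the present change. Compound 4 `O=C(O)c1ccccc1-c1ccc(CCc2ncc(Cc3ccccc3)[nH]2)cc1` arises from compound 2 by phenyl in place of neopentyl on a saturated chain carbon bound to an aromatic carbon. Nothing measured bears directly on this exchange; compound 1 and compound 3 carry a different group on the imidazole and also differ at the linker, so their values show only that other arrangements of the chain give far higher numbers than compound 2. Within the data shown here, with no comparable step in hand, some loss from compound 2 is expected but of uncertain size, and the step of a 6.4-fold higher number from compound 2 to compound 4 (0.81 log units; beyond the scatter) is an estimate only. Compound 4 is therefore expected at 250 nM, within 40 nM to 1500 nM.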

Compound 4, half-maximal effective concentration: 205 nM
For compound 4 the middle estimate is 1.2-fold (0.09 log units) above the measured one; low and high end bracket the measured number.
By their numbers in this assay, from the lowest: compound 2; then compound 4; then compounds 1 and 3 (each within the scatter of the next).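

For this assay the series shows a 5.3-fold higher number from compound 2 to compound 4 (0.72 log units; beyond the scatter) with phenyl in place of neopentyl on a saturated chain carbon bound to an aromatic carbon. Within the data shown here, this is the first reading of this position: the group held there does change the number, yet the step stays modest, so activity at this receptor does not depend on neopentyl and persists with a six-membered aromatic ring in its place. No measurement at hand accounts for the size of this step.

With only these two groups, the contribution of the ring cannot be separated from the loss of the open branched chain; a cyclohexyl group at this place would divide the two. Also open, as far as these compounds go, is whether a methoxy group or an amine on the phenyl ring would bring the number back toward that of compound 2.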